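This account rests on a few compounds, and the source may have more. Where it says the series, first, only, none or still open, it means among the compounds named here.

Compound 1 `O=C(/C(=N/O)Nc1ccc(F)c(Br)c1)C1CCN(S(=O)(=O)Nc2ccccc2)CC1` gives 65700 nM in an assay for inhibition of Tryptophan 2,3-dioxygenase (Homo sapiens), with a stated time of 1 h; on this read-out higher numbers stand for weaker inhibition and lower numbers for stronger inhibition. Compound 2 `O=C(/C(=N/O)Nc1ccc(F)c(Br)c1)C1CCN(c2ccccc2)CC1` carries a phenyl where compound 1 carries a phenylsulfamoyl group. In this assay compound 2 gives > 100000 nM, which is a limit of the assay rather than a number. The step of an at least 1.5-fold higher number from compound 1 to compound 2 (0.18 log units; that floor lies within the scatter) is therefore known only as a floor because of the limit of > 100000 nM in this assay, at which 1 of the 2 values shown sits. Compound 3 `O=C(/C(=N/O)Nc1ccc(F)c(Br)c1)C1CCN(C(=O)c2ccccc2)CC1` changes compound 2 by benzoyl in place of phenyl on an amine nitrogen in a ring. Going by the values given here, no measured step covers this change; the only measured step was small and lies within the scatter. Relative to compound 2, compound 3 is expected to move by an at least 1.2-fold lower number from compound 2 to compound 3 (0.09 log units; that floor lies within the scatter). Compound 3 is estimated at 80000 nM, within 30000 nM to 200000 nM.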

Compound 3, half-maximal inhibitory concentration: > 100000 nM
Compound 3 gave a limit, no number; the forecaster's own chance of this, stated with the estimate: 50%; at least 1.2-fold (0.09 log units) between middle value and limit.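

Benzoyl on this amine nitrogen in a ring, like phenyl, leaves no readable number: in this assay compound 3 gives > 100000 nM, which is a limit of the assay and not a number. Benzoyl in place of phenylsulfamoyl gives an at least 1.5-fold higher number from compound 1 to compound 3 (0.18 log units; that floor lies within the scatter). The step from compound 2 to compound 3 cannot be read because both values are limits: the limit of > 100000 nM in this assay, at which 2 of the 3 values shown sit.

Going by these compounds, whether a phenylsulfonyl or a methylsulfamoyl group on this nitrogen would give a readable number stays open. So does which part of the phenylsulfamoyl group of compound 1 matters.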